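Shortening the chain terminus to a methyl ester

The source may report more compounds than this note shows. Statements on the series, on what has been measured and on what is new or still open speak of the compounds shown alone.

Measured compounds in a functional assay on CCRF-CEM cells (Homo sapiens) for antiproliferative activity; a higher number here means a weaker inhibitor of growth, a lower number a stronger inhibitor of growth:

compound 1, `COCCCCCCCCCCC/C=C1\CC(CO)(COC(=O)C(C)(C)C)OC1=O`, gives 0.701 ug/mL
compound 2, `CC(=O)OCCCCCCCCCCCCCCC/C=C1\CC(CO)(COC(=O)C(C)(C)C)OC1=O`, gives 7.55 ug/mL
compound 3, `CC(C)(C)C(=O)OCCCCCCCCCCCCCCC/C=C1\CC(CO)(COC(=O)C(C)(C)C)OC1=O`, gives > 10 ug/mL

For compound 3 this value is a limit of the assay rather than a number, as noted in the limit of > 10 ug/mL in this assay, at which 1 of the 3 values shown sits. Compound 1 sits clearly below the others, and the steps of an 11-fold higher number from compound 1 to compound 2 (1.03 log units; beyond the scatter) and an at least 14-fold higher number from compound 1 to compound 3 (1.15 log units; beyond the scatter) are both large. The step of an at least 1.3-fold higher number from compound 2 to compound 3 (0.12 log units; that floor lies within the scatter), by contrast, only sets a floor that stays within the scatter.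

Compound 4, `COC(=O)CCCCCCCCCCCCCC/C=C1\CC(CO)(COC(=O)C(C)(C)C)OC1=O`, has not been measured. It differs from compound 3 by methoxycarbonyl in place of (((tert-butyl)carbonyl)oxy)methyl on a saturated chain carbon, ten or more bonds along the chain from a double-bonded chain carbon. Within the data shown here, no measured step swaps an ester-bearing terminus for a shorter terminal methyl ester, so the two large steps from compound 1 are the only guide: both show that ester-terminated long chains weaken growth inhibition compared with the methoxy terminus of compound 1. Compound 4 keeps an ester terminus on a shorter chain, and it is therefore expected to land between compound 1 and compound 2, with an expected step of an at least 2.5-fold lower number from compound 3 to compound 4 (0.39 log units; beyond the scatter) toward a stronger inhibitor than compound 3. Compound 4 is estimated at 4 ug/mL, within a range of 1.2 ug/mL to 10 ug/mL.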

Compound 4, concentration for 50% growth inhibition: 0.691 ug/mL
Estimate against measurement, compound 4: 5.8-fold (0.76 log units) above; measured number below the stated range.
By their numbers in this assay, from the lowest: compounds 4 and 1 (each within the scatter of the next); then compound 2. At a limit, above all of these: compound 3.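

In this assay, an ester at the chain end does not by itself go with weak growth inhibition, as the methoxycarbonyl terminus of compound 4 stands level with the methoxy terminus: a 1.0-fold lower number from compound 1 to compound 4 (0.01 log units; within the scatter). Among the ester-terminated chains, the form of the terminus carries a large difference, with methoxycarbonyl in place of acetoxymethyl giving an 11-fold lower number from compound 2 to compound 4 (1.04 log units; beyond the scatter), and methoxycarbonyl in place of (((tert-butyl)carbonyl)oxy)methyl giving an at least 14-fold lower number from compound 3 to compound 4 (1.16 log units; beyond the scatter). That last step is only a floor, as compound 3 stands at a limit of the assay rather than at a number: the limit of > 10 ug/mL in this assay, at which 1 of the 4 values shown sits.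

The compounds shown do not separate the shorter chain from the change of ester group, as both differ together in compound 4. From the compounds shown here alone, whether a carboxylic acid or an amide at this chain end would keep the level of compound 4 also remains open.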